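Cyano on the aromatic ring: cytotoxicity expectation for compound 3

This account rests on a few compounds, and the source may have more. Where it says the series, first, only, none or still open, it means among the compounds named here.

Among the measured compounds shown here, compound 1 `OCc1cn(Cc2ccccc2)nn1` and compound 2 `CCc1nnn(Cc2ccccc2)c1CCO` share the same core, and no single-change step links them, so only their separate readings are given. In an ADME assay on cells (Mus musculus) for cytotoxicity, read by MTT assay (on this read-out higher numbers stand for lower toxicity in this test and lower numbers for higher toxicity in this test), compound 1 gives > 100000 nM, which is a limit of the assay rather than a number. In this assay compound 2 likewise gives > 100000 nM, again a limit and not a measured value. For the measured compounds named here, both readings sit at the same boundary, as summarised by the limit of > 100000 nM in this assay, at which 2 of the 2 values shown sit; no step has been measured, and nothing is known about how either compound would read below that boundary.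

Compound 3 `CCc1nnn(Cc2cccc(C#N)c2)c1CCO` is the next member. It differs from compound 2 by cyano in place of hydrogen on an aromatic carbon. With only two limits to go on, no step beyond the usual scatter in this assay is expected in either direction, which is what the estimated step of a number no higher from compound 2 to compound 3 (the limit leaves the size open) means. Compound 3 is expected to give 100000 nM, within a range of 50000 nM to 200000 nM, and the reading is expected to come back as a limit more often than as a number.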

Compound 3, half-maximal cytotoxic concentration: > 100000 nM
Compound 3 was reported as a limit; the forecaster's own chance of this, stated with the estimate: 80%; the middle value sits exactly at the limit.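

Compound 2 and compound 3 both read as limits in this assay, so no step for cyano in place of hydrogen on an aromatic carbon can be read between them: the limit of > 100000 nM in this assay, at which 3 of the 3 values shown sit.
The compounds shown leave open whether any change on the shared core would give a number rather than a limit in this assay and what size of step it would show.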